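A few compounds are considered here, and "the series" means these few. Any claim that something is new, unique, unknown or untested is made for them only; others in the source may bear on it.

Three compounds have been measured in a functional assay on OVCAR-8 cells (Homo sapiens) for inhibition; on this read-out higher numbers stand for weaker inhibition of growth and lower numbers for stronger inhibition of growth:
Compound 1, `C=C1CCC[C@H]2[C@](C)(CC[C@]3(C)CC[C@H]([C@@H](C)C(=O)O)OO3)[C@@H](C)CC[C@]12C`, gives 1570 nM.
Compound 2, `C=C1CCCC(C)(C)C1CC[C@]1(C)CC[C@H]([C@@H](C)C(=O)OC)OO1`, gives 5760 nM.
Compound 3, `CC1=C(CC/C(C)=C/CC[C@@]2(C)CC[C@@H]([C@H](C)C(=O)O)OO2)C(C)(C)CCC1`, is reported only as a limit, > 100000 nM.

Compound 3 stands apart from the other two. Compound 1 and compound 2 each give a number in this assay, whereas compound 3 reaches only the limit of the assay, (the limit of > 100000 nM in this assay, at which 1 of the 3 values shown sits), so its growth inhibition is not pinned down by a number. Among the measured compounds shown here, no two of the three measured compounds differ in a single place, so no measured step between them is available.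

Compound 4, `CC1=C(CC/C(C)=C/CC[C@@]2(C)CC[C@H]([C@H](C)C(=O)O)OO2)C(C)(C)CCC1`, is the next compound. Relative to compound 3 the change is this: the two compounds have the same atoms and bonds and differ only in configuration as drawn: 1 of 4 stereo elements differ; a stereocentre at a saturated ring carbon is drawn S in compound 3 and R in compound 4. For the measured compounds named here, nothing among the measured compounds shows how such a change in configuration alters growth inhibition in this assay. The step from compound 3 to compound 4 therefore cannot be anchored on either side. A reading at or near the limit is taken as the most likely outcome for compound 4, while a step in either direction beyond the scatter cannot be excluded.

The expectation for compound 4 is 100000 nM, with a range from 20000 nM to 300000 nM. The step this estimate implies is expected to be a number no higher from compound 3 to compound 4 (the limit leaves the size open).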

Compound 4, concentration for 50% growth inhibition: > 5000 nM
Compound 4: only a limit was reported; the forecaster's own chance of this, stated with the estimate: 70%; the middle value does not contradict the limit.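

In this assay compound 4 is reported only as a limit, > 5000 nM. Among the compounds shown here, compound 3 is likewise reported only as a limit, > 100000 nM, so no step from one to the other can be read for compound 3 and compound 4. The compounds shown leave open whether the configuration at this saturated ring carbon alters growth inhibition at all.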